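The source may report more compounds than this note shows. Statements on the series, on what has been measured and on what is new or still open speak of the compounds shown alone.

In a functional assay on SW480 cells (Homo sapiens) for cytotoxicity, read by MTT assay, with a stated time of 48 h (a higher number here means a weaker inhibitor, a lower number a stronger inhibitor), compound 3 (`COc1cc([C@H]2C[C@@]2(CO)C(=O)Nc2ccccc2Cl)cc(OC)c1OC`) reads > 100000 nM, which is a limit and not a number. Compound 4 (`COc1cc([C@H]2C[C@@]2(CO)C(=O)NCc2ccc(C)cc2)cc(OC)c1OC`) differs from it on an amide-type nitrogen: 4-methylbenzyl in place of 2-chlorophenyl on an amide-type nitrogen. The entering 4-methylbenzyl also sits on that nitrogen in compound 1 (`COc1cc([C@@H]2C[C@]2(CO)C(=O)NCc2ccc(C)cc2)cc(OC)c1OC`) and compound 2 (`COc1cc([C@@H]2C[C@@]2(CO)C(=O)NCc2ccc(C)cc2)cc(OC)c1OC`). Their step, a 2.8-fold higher number from compound 1 to compound 2 (0.45 log units; beyond the scatter), is modest and involves configuration alone, as shown by the fact that compounds 1 and 2 differ only in the configuration as drawn. Going by the values given here, no measured step covers the exchange of 2-chlorophenyl for 4-methylbenzyl. Since compound 1 gives 26800 nM and compound 2 gives 76300 nM, a lower number than that of compound 3 is expected for compound 4, of uncertain size. The expected step is an at least 2.2-fold lower number from compound 3 to compound 4 (0.34 log units; beyond the scatter). For compound 4, the estimated value is 45000 nM, with an expected range of 15000 nM to 100000 nM.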

Compound 4, half-maximal inhibitory concentration: > 100000 nM
Compound 4 gave a limit, no number; the forecaster's own chance of this, stated with the estimate: 20%; middle value at least 2.2-fold (0.34 log units) from the limit.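

In this assay compound 4 reads > 100000 nM, a limit of the assay and not a number, so the step with compound 3 cannot be read. Inverting both stereocentres gives an at least 3.7-fold higher number from compound 1 to compound 4 (0.57 log units; beyond the scatter), the first evidence on the mirror-image pair: the fact that compounds 1 and 4 differ only in the configuration as drawn. Inverting one gives an at least 1.3-fold higher number from compound 2 to compound 4 (0.11 log units; that floor lies within the scatter), and that floor gives no firm order for this pair: the fact that compounds 2 and 4 differ only in the configuration as drawn.

The effect of the group on the amide-type nitrogen remains unresolved in this configuration. Also open, from the compounds shown here alone, is how 2-chlorophenyl, or a longer chain such as 2-phenylethyl, reads on the configuration of compound 1.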